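Swapping a triazole-diol tail for a methylpiperazine chain

This account rests on a few compounds, and the source may have more. Where it says the series, first, only, none or still open, it means among the compounds named here.

Compound 1 `O=C1c2c[n+]([O-])c3ccccc3c2C(=O)c2c1c1ccccc1n2Cc1cn(CC(O)CO)nn1` carries the shared core of this set with a 1-(2,3-dihydroxypropyl)-1H-1,2,3-triazol-4-yl group on a saturated chain carbon bound to an aromatic nitrogen. Among the measured compounds shown here, in a functional assay on HCT-116 cells (Homo sapiens) for cytotoxicity, read by MTT assay, with a stated time of 72 h (on this read-out lower numbers stand for stronger inhibition and higher numbers for weaker inhibition), compound 1 gives 250 nM, the second highest of the three numbers known. Compound 2 `CC1(C)OC[C@H](Cn2cc(Cn3c4c(c5ccccc53)C(=O)c3c[n+]([O-])c5ccccc5c3C4=O)nn2)O1` gives 130 nM and compound 3 `CC1(C)OC[C@@H](Cn2cc(Cn3c4c(c5ccccc53)C(=O)c3c[n+]([O-])c5ccccc5c3C4=O)nn2)O1` gives 340 nM; both replace the diol with a 2,2-dimethyl-1,3-dioxolan-4-yl ring and differ from each other only in configuration (the fact that compounds 2 and 3 differ only in the configuration as drawn). The steps of a 1.9-fold lower number from compound 1 to compound 2 (0.28 log units; within the scatter) and a 1.4-fold higher number from compound 1 to compound 3 (0.13 log units; within the scatter) stay within the scatter, while a 2.6-fold higher number from compound 2 to compound 3 (0.42 log units; beyond the scatter) is a modest shift.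

Compound 4 `CN1CCN(CCCCCn2c3c(c4ccccc42)C(=O)c2c[n+]([O-])c4ccccc4c2C3=O)CC1` changes a different part: 4-(4-methylpiperazin-1-yl)butyl in place of 1-(2,3-dihydroxypropyl)-1H-1,2,3-triazol-4-yl on a saturated chain carbon bound to an aromatic nitrogen. For the measured compounds named here, none of the measured steps touch the triazole itself, so they give no direct guide to the size or direction of this change; they only show that the tail beyond the core has been tolerant of alteration so far. The expectation for compound 4 in this assay is therefore a step near zero, a 1.1-fold lower number from compound 1 to compound 4 (0.06 log units; within the scatter), with wide uncertainty, giving an estimated value of 220 nM (range 60 nM to 800 nM).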

Compound 4, half-maximal inhibitory concentration: 1220 nM
Compound 4: the middle estimate sits 5.5-fold (0.74 log units) below what was measured, outside the stated range (above it).
By their numbers in this assay, from the lowest: compounds 2, 1 and 3 (each within the scatter of the next, the first and the last beyond it); then compound 4.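

Replacing the whole triazole tail of compound 1 with the methylpiperazine chain raises the number (a 4.9-fold higher number from compound 1 to compound 4 (0.69 log units; beyond the scatter)), and this is the first change from compound 1 shown here that goes beyond the scatter. On a saturated chain carbon bound to an aromatic nitrogen, the tail is therefore less freely exchangeable than compounds 1, 2 and 3 alone suggested, although a cytotoxic effect remains with the new chain. Nothing given here explains this shift.

This single swap removes the triazole and the diol while bringing in the piperazine ring and the all-carbon chain, so the compounds shown cannot say which of these parts accounts for the step. A 4-(morpholin-4-yl)butyl group, or a triazole carrying a 4-methylpiperazin-1-yl group, would begin to separate these parts.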